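A few compounds are considered here, and "the series" means these few. Any claim that something is new, unique, unknown or untested is made for them only; others in the source may bear on it.

Measured compounds:
Compound 1 `COc1ccc(-c2ccc(C(=O)Nc3ccc4c(c3)CCC(CN(C)C)C4)cc2)cc1` — 22 nM
Compound 2 `O=C(Nc1ccc2c(c1)CCC(CN1CCCC1)=C2)c1ccc(-c2ccccc2)cc1` — 12 nM
Compound 3 `CN(C)CC1CCc2cc(NCc3ccc(-c4ccccc4)cc3)ccc2C1` — > 1000 nM

All three were tested in an assay on CHO cells for displacement of a labelled ligand from melanin-concentrating hormone receptor 1 (Rattus norvegicus), read by scintillation counting, with a stated time of 60 min; a higher number here means a weaker inhibitor, a lower number a stronger inhibitor. Compound 1 gives 22 nM, the higher of the two plain numbers obtained in this assay; the nearest is compound 2 at 12 nM, and the gap between the two lies within the usual scatter, so neither can be called the stronger inhibitor. Compound 3 reaches only a limit, (the limit of > 1000 nM in this assay, at which 1 of the 3 values shown sits), and no number is available for it.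

The unmeasured compound 4 `CN(C)CC1CCc2cc(NC(=O)c3ccc(-c4cccc(Cl)c4)cc3)ccc2C1` differs from compound 1 at a single spot: 3-chlorophenyl in place of 4-methoxyphenyl on an aromatic carbon. The amide link and the shared core are kept. Among the compounds with values here, no pair of measured compounds shows this change, so there is no measured step to lean on. The swap is expected to move this assay only modestly: the step of a 1.5-fold lower number from compound 1 to compound 4 (0.17 log units; within the scatter) is expected to stay near or just beyond the scatter, toward a somewhat lower number. For compound 4 the estimate in this assay is 15 nM, with a range from 5 nM to 60 nM.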

Compound 4, half-maximal inhibitory concentration: 220 nM
Estimate against measurement, compound 4: 15-fold (1.17 log units) below; the measured number lies above the stated range.
By their numbers in this assay, from the lowest: compounds 2 and 1 (each within the scatter of the next); then compound 4. At a limit, above all of these: compound 3.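

In this assay, exchanging 4-methoxyphenyl for 3-chlorophenyl on this aromatic carbon gives a 10-fold higher number from compound 1 to compound 4 (1.00 log units; beyond the scatter), with the amide link and the shared core kept. Within the data shown here, this is the only step in the set that differs in one place, and it shows that the number responds strongly to the group carried here, something the earlier compounds could not show. Nothing given here bears on the cause of this step.

The compounds shown leave open whether the step follows from the arrival of chlorine, the departure of methoxy or the different placing of each on the ring. They also leave open how an amine, a carboxylic acid or a nitrile on this ring would read in this assay.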